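The source may report more compounds than this note shows. Statements on the series, on what has been measured and on what is new or still open speak of the compounds shown alone.

Measured compounds:

Compound 1, `O=C(NCc1ccc(F)cc1Cl)c1cc(Cl)ccc1O`, gives 30900 nM.
Compound 2, `O=C(NCc1ccc(Cl)cc1Cl)c1cc(Cl)ccc1O`, gives 30900 nM.
Compound 3, `C[C@@H](NC(=O)c1cc(Cl)ccc1O)c1ccc(Cl)cc1`, gives 31100 nM.

These three compounds were tested in an ADME assay on A549 cells (Homo sapiens) for cytotoxicity, read by resazurin assay, with a stated time of 48 h; a higher number here means that more compound is tolerated, a lower number that less compound is tolerated. Compound 1 and compound 2 share a core and differ in one place: fluoro in place of chloro on an aromatic carbon. For this change the measurement moved no change at the digits printed from compound 2 to compound 1 (within the scatter), so within this series the swap made no visible difference to how much compound the cells tolerate. Compound 3 belongs to the same family but carries a different core; the difference between the core of compound 3 and the core of compound 2 is not broken down here. Its value sits within the scatter of compound 1 and compound 2, so no order among the three can be read from these numbers.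

Compound 4, `C[C@@H](NC(=O)c1cc(Cl)ccc1O)c1ccc(F)cc1`, has not yet been measured. It is related to compound 3 in the following way: fluoro in place of chloro on an aromatic carbon. Within the data shown here, this is the same kind of change as the one from compound 2 to compound 1, though not the same: in the earlier pair the changed carbon was also meta to a chloro group, while in compound 3 no such group stands nearby. On this basis the step is expected to be a 1.0-fold lower number from compound 3 to compound 4 (0.00 log units; within the scatter), because the earlier instance gave no change at the digits printed from compound 2 to compound 1 (within the scatter). Compound 4 is therefore estimated to give 31000 nM, with a likely range from 15000 nM to 62000 nM.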

Compound 4, half-maximal cytotoxic concentration: > 200000 nM
Compound 4 was reported as a limit (the forecaster's own chance of this, stated with the estimate: 20%); middle value at least 6.4-fold (0.80 log units) from the limit.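

In this assay, fluoro in place of chloro on an aromatic carbon gave an at least 6.4-fold higher number from compound 3 to compound 4 (0.80 log units; beyond the scatter), so the swap that left the earlier pair level did not give the same result on this second core: the same change on two cores in this assay, no change at the digits printed (within the scatter) from compound 2 to compound 1 and an at least 6.4-fold higher number (0.80 log units; beyond the scatter) from compound 3 to compound 4, at least 6.4-fold (0.80 log units) apart, beyond the scatter of two such steps

Compound 4 gives > 200000 nM, which is a limit of the assay and not an exact number, and it is the only limit among the compounds shown: the limit of > 200000 nM in this assay, at which 1 of the 4 values shown sits.

Two pairs show that the result of this swap can depend on the core, but they cannot show why the cores differ, how large the step from compound 3 to compound 4 truly is, or what the swap would do on other cores in the series.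

The compounds shown leave open whether the result for compound 4 is particular to fluoro or would also appear with another group in the same place, such as methoxy, methyl or an amine. As far as these compounds go, it also remains open whether further cores, for example one with a longer chain in place of the short one in compound 4, would follow the pattern of compound 1 or that of compound 4.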